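Inverting the stereocentre of compound 3: working notes

A few compounds are considered here, and "the series" means these few. Any claim that something is new, unique, unknown or untested is made for them only; others in the source may bear on it.

Measured in a functional assay on HL-60 cells (Homo sapiens) for antiproliferative activity, read by CCK-8 assay, with a stated time of 72 h; on this read-out higher numbers stand for weaker inhibition and lower numbers for stronger inhibition:
- compound 1 `CC(=O)Oc1cc2c(CC[C@@H]3OC(C)(C)OC3(C)C)c(C)ccc2cc1C(C)C`: 16000 nM
- compound 2 `CC(=O)Oc1cc2c(CC[C@H]3OC(C)(C)OC3(C)C)c(C)ccc2cc1C(C)C`: 17200 nM
- compound 3 `Cc1ccc2cc(C(C)C)c(O)cc2c1CC[C@@H]1OC(C)(C)OC1(C)C`: 45500 nM

Compound 3 gives the highest of the three numbers, at 45500 nM, and lies beyond the scatter from both others. The next structure is compound 4 `Cc1ccc2cc(C(C)C)c(O)cc2c1CC[C@H]1OC(C)(C)OC1(C)C`, and the change is the two compounds have the same atoms and bonds and differ only in configuration as drawn: 1 of 1 stereo elements differ; a stereocentre at a saturated ring carbon is drawn S in compound 3 and R in compound 4.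

The measured step closest to this change is a 1.1-fold higher number from compound 1 to compound 2 (0.03 log units; within the scatter). The evidence attached to that step is the fact that compounds 1 and 2 differ only in the configuration as drawn, so it shows the same kind of inversion in the acetyl pair. The other measured step, a 2.8-fold higher number from compound 1 to compound 3 (0.45 log units; beyond the scatter), places hydrogen in place of acetyl on an oxygen on an aromatic ring. It alters no configuration and only sets the level from which compound 4 starts.

The estimated step is a 1.1-fold higher number from compound 3 to compound 4 (0.02 log units; within the scatter), so none beyond the scatter is expected in this assay. The estimate for compound 4 is 48000 nM, with an expected range of 26000 nM to 85000 nM.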

Compound 4, half-maximal inhibitory concentration: 49400 nM
The estimate for compound 4 lay 1.0-fold (0.01 log units) below the measured number, and the stated range covers the measured number.
By their numbers in this assay, from the lowest: compounds 1 and 2 (each within the scatter of the next); then compounds 3 and 4 (each within the scatter of the next).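

In this assay the inversion gives a 1.1-fold higher number from compound 3 to compound 4 (0.04 log units; within the scatter), so the stereocentre at the saturated ring carbon makes no difference beyond the scatter with hydrogen on the aromatic oxygen, which the earlier compounds showed only with acetyl there: the fact that compounds 3 and 4 differ only in the configuration as drawn

Hydrogen in place of acetyl on that oxygen, earlier seen only with the S drawing, now also appears with the R drawing, as a 2.9-fold higher number from compound 2 to compound 4 (0.46 log units; beyond the scatter), and the two steps agree: the same change on two cores in this assay, a 2.8-fold higher number (0.45 log units; beyond the scatter) from compound 1 to compound 3 and a 2.9-fold higher number (0.46 log units; beyond the scatter) from compound 2 to compound 4, 1.0-fold (0.00 log units) apart, within the scatter of two such steps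

Across these four compounds, the acetyl change moves the number beyond the scatter and the inversion does not, whichever group sits on the oxygen.

As far as these compounds go, it remains open whether a longer acyl chain or a carbamate on that oxygen would move the number beyond the level of the acetyl pair. From the compounds shown here alone, it also remains open whether the configuration would still make no difference if the saturated ring carried an amine or a carboxylic acid.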